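The source may hold more compounds than are shown below. What is called first, only, known or untested is meant among the compounds shown, and "the series" means these compounds.

Measured so far:
Compound 1, `CCCCCCCCCCCCCCCCCC(=O)O[C@H]1[C@H](O)[C@H](n2ccc(N)nc2=O)O[C@@H]1CO`: 0.13 ug/mL
Compound 2, `CCCCCCCCCCCCCCCCCCCC(=O)OC[C@H]1O[C@@H](n2ccc(N)nc2=O)[C@@H](O)[C@@H]1OC(=O)CCCCCCCCCCCCCCCCCCC`: > 10 ug/mL

Of the compounds shown here, two have been tested in a functional assay on HeLa cells (Homo sapiens) for cytotoxicity, read by cell counting, with a stated time of 48 h; a higher number here means that more compound is needed for the effect, a lower number that less compound is needed. Within the data shown here, compound 1 gives 0.13 ug/mL, the only finished number in the set. Compound 2 gives > 10 ug/mL, which is a limit of the assay rather than a number; it sits at the limit of > 10 ug/mL in this assay, at which 1 of the 2 values shown sits. Compound 1 therefore stands as the sole reference point for what follows.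

Compound 3, `CCCCCCCCCCCC(=O)O[C@H]1[C@H](O)[C@H](n2ccc(N)nc2=O)O[C@@H]1CO`, has not yet been measured. It keeps the whole core of compound 1 and differs in the ester chain only: hydrogen in place of hexyl on a saturated chain carbon, ten or more bonds along the chain from a carbonyl carbon. Among the measured compounds shown here, no pair of measured compounds differing in a single place is available, so the size of this step cannot be read from existing data. The expectation is that the step from compound 1 to compound 3 stays small, at most a 1.5-fold higher number from compound 1 to compound 3 (0.19 log units; within the scatter), in this assay. For compound 3 the estimate is 0.2 ug/mL, with a range from 0.05 ug/mL to 0.8 ug/mL.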

Compound 3, concentration for half-maximal effect: 0.08 ug/mL
Estimate against measurement, compound 3: 2.5-fold (0.40 log units) above; low and high end bracket the measured number.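

Among these compounds, replacing hexyl with hydrogen on a saturated chain carbon gives the first single change with a readable size in this assay, namely a 1.6-fold lower number from compound 1 to compound 3 (0.21 log units; within the scatter). Among the compounds shown here, the outer part of the ester chain can therefore differ by this much while the two compounds stay indistinguishable in this measurement, which the earlier compounds, having no single-place pair, could not show. Nothing among the data at hand accounts for this tolerance.

Two chain lengths on one core say little about how far this tolerance reaches, so a still shorter chain or a longer chain remains an open case. Equally open, going by these compounds, is what an amine or a carboxylic acid at the end of the chain would do.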